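This account rests on a few compounds, and the source may have more. Where it says the series, first, only, none or still open, it means among the compounds named here.

The measured compounds are compound 1 `Fc1cc(Cl)ccc1-c1ccc(Cn2nnc3ccccc32)cn1`, compound 2 `Fc1cc(Cl)ccc1-c1ccc(Cn2nnc3c(F)cccc32)cn1` and compound 3 `Brc1cccc2c1nnn2Cc1ccccc1`. In an ADME assay on microsomes from liver (Mus musculus, strain NMRI) for metabolic stability, tested at 2.5 uM (a higher number here means faster removal of the compound, a lower number slower removal), compound 1 gives 3.4 mL/min/g, compound 2 gives 2.2 mL/min/g and compound 3 gives 2.3 mL/min/g.

Compound 2 differs from compound 1 by fluoro in place of hydrogen on an aromatic carbon, and this change gave a 1.5-fold lower number from compound 1 to compound 2 (0.19 log units; within the scatter). The value of compound 3 lies within the scatter of both compound 2 and compound 1, so the three numbers cannot be ordered. How the core of compound 3 differs from the core of compound 1 is not broken down here.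

Compound 4 `Fc1cccc(Cn2nnc3c(Br)cccc32)c1` is the unmeasured member. It differs from compound 3 by fluoro in place of hydrogen on an aromatic carbon. This is the same kind of change as that from compound 1 to compound 2, but not the same: there the fluoro enters on a ring that is part of a fused or bridged system of two rings, ortho to a fused ring and meta to a fused ring, whereas here it enters on a six-membered aromatic ring of carbon only, meta to a large group. Because the earlier step was a 1.5-fold lower number from compound 1 to compound 2 (0.19 log units; within the scatter), a step of about the same small size is expected in this assay, namely a 1.4-fold lower number from compound 3 to compound 4 (0.13 log units; within the scatter). Compound 4 is therefore estimated at 1.7 mL/min/g, with a range of 0.9 mL/min/g to 3.5 mL/min/g.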

Compound 4, intrinsic clearance in a liver preparation (reported as CLH), per the amount of preparation that the assay uses: 1.3 mL/min/g
For compound 4 the middle estimate is 1.3-fold (0.12 log units) above the measured one; the range from low to high includes it.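

In this assay, fluoro in place of hydrogen on an aromatic carbon gave a 1.8-fold lower number from compound 3 to compound 4 (0.25 log units; within the scatter) and so, like the earlier step, this one cannot be told apart from the scatter of repeated measurements. Set side by side, the two steps do not differ beyond that scatter: the same change on two cores in this assay, a 1.5-fold lower number (0.19 log units; within the scatter) from compound 1 to compound 2 and a 1.8-fold lower number (0.25 log units; within the scatter) from compound 3 to compound 4, 1.1-fold (0.06 log units) apart, within the scatter of two such steps. This shows that the change carried from one core to the other without a step that stands out, even though the fluoro enters a different kind of ring in each case, but with both steps within the scatter it does not establish a real effect of the fluoro on either core, and two cores cannot define a rule for the series.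

The compounds shown leave open whether a different group on the same aromatic carbon, such as a methoxy, an amine or a carboxylic acid, would give a step beyond the scatter in this assay. They also leave open whether fluoro would behave the same way on further cores or at other places on these rings.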